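This account rests on a few compounds, and the source may have more. Where it says the series, first, only, none or still open, it means among the compounds named here.

Measured compounds in a functional assay on SR cells (Homo sapiens) for inhibition, read by sulforhodamine B assay, with a stated time of 48 h; on this read-out higher numbers stand for weaker inhibition of growth and lower numbers for stronger inhibition of growth:
- compound 1 `COc1cc(-c2nn(-c3cccc(NC(=O)Nc4cc(C(F)(F)F)cc(C(F)(F)F)c4)c3)cc2-c2ccncc2)ccc1Cl`: 3970 nM
- compound 2 `O=C(Nc1cccc(-n2cc(-c3ccncc3)c(-c3ccc(Cl)c(O)c3)n2)c1)Nc1ccc(Cl)c(Cl)c1`: 15000 nM

Within the data shown here, compound 1 stands at the lowest of the two numbers so far in this assay. Compound 2 sits at a higher number, and the gap between the two is beyond the usual scatter, so compound 1 inhibits growth more strongly than compound 2 on this read-out. Among the measured compounds shown here, no pair of measured compounds differs in a single place, so no measured step is available as a guide.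

Compound 3 `COc1cc(-c2nn(-c3cccc(NC(=O)Nc4cccc(C(F)(F)F)c4)c3)cc2-c2ccncc2)ccc1Cl` is the next compound to be measured in this assay. It differs from compound 1 in one place: hydrogen in place of trifluoromethyl on an aromatic carbon. One of the two trifluoromethyl groups on the terminal phenyl urea is thus taken away, while the rest of the structure, including the shared core and the chloro-methoxyphenyl, is kept.

For the measured compounds named here, with no single-change step measured, the expected size of the step in this assay rests on the change alone. The step from compound 1 to compound 3 is expected to be small, most likely toward a somewhat higher number, and it may well stay within the scatter: the estimate for this step is a 1.5-fold higher number from compound 1 to compound 3 (0.18 log units; within the scatter). Compound 3 is accordingly expected to give about 6000 nM in this assay, with a plausible range from 2000 nM to 18000 nM.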

Compound 3, concentration for total growth inhibition: 2840 nM
The estimate for compound 3 lay 2.1-fold (0.32 log units) above the measured number; measured number inside the range.
By their numbers in this assay, from the lowest: compounds 3 and 1 (each within the scatter of the next); then compound 2.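

In this assay, among these compounds, hydrogen in place of trifluoromethyl on an aromatic carbon of the terminal phenyl urea gives a 1.4-fold lower number from compound 1 to compound 3 (0.15 log units; within the scatter), the first single-change step. On this read-out, compound 3 and compound 1 cannot be told apart, so this position accepts the loss of one trifluoromethyl group, with its 4 heavy atoms, without a measurable shift in the number, and the second trifluoromethyl group is not required to hold growth inhibition at the level of compound 1. Nothing measured on these compounds speaks to why the step is this small, and one step in one cell line gives no basis for an explanation.

Still open, from the compounds shown here alone, is whether this aromatic carbon responds at all to groups of a different kind, such as a methoxy group, an amine or a carboxylic acid, since hydrogen and trifluoromethyl are the only two substituents compared here. Also open, going by these compounds, is whether the remaining trifluoromethyl group can give way to hydrogen as well, leaving an unsubstituted phenyl on the urea, or whether at least one such group has to stay.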